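Series notes: aryl in place of hydroxyalkyl, spleen-cell toxicity

The compounds below may be only part of what the source reports. "The series", "measured", "known", "first", "only" and "open" are said of these compounds alone.

compound 1 `CCC(O)Cc1cn(CC(=O)NCc2ccccc2)nn1`: 630 uM
compound 2 `CC(C)(O)c1cn(CC(=O)NCc2ccccc2)nn1`: 1600 uM
compound 3 `COc1cc(OC)cc(-c2cn(CC(=O)NCc3ccccc3)nn2)c1`: "non-toxic" (no number reported) (reported without a number)

In an ADME assay on cells (spleen, Mus musculus, strain C57BL/6) for inhibition, read by flow cytometry and propidium iodide staining, with a stated time of 24 h, at 37 degrees C (a higher number here means that more compound is needed for the effect, a lower number that less compound is needed), compound 2 gives 1600 uM, the highest of the two numbers in hand. Compound 1 gives 630 uM. For the measured compounds named here, the only measured step, a 2.5-fold higher number from compound 1 to compound 2 (0.40 log units; beyond the scatter), exchanges one hydroxyalkyl group for another and so bears only loosely on the move to compound 4 `COc1cccc(-c2cn(CC(=O)NCc3ccccc3)nn2)c1`, where (3-methoxyphenyl in place of 1-hydroxy-1-methylethyl on an aromatic carbon). Compound 3, an aryl analog, returned no number in this assay. Going by the values given here, with no aryl-for-hydroxyalkyl step measured, the expectation for compound 4 is a step of about a 1.1-fold lower number from compound 2 to compound 4 (0.03 log units; within the scatter), no direction beyond the scatter. Compound 4 is therefore estimated at 1500 uM, within 500 uM to 5000 uM.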

Compound 4, concentration for half-maximal effect: 840 uM
Compound 4: the middle estimate sits 1.8-fold (0.25 log units) above what was measured; low and high end bracket the measured number.
By their numbers in this assay, from the lowest: compounds 1, 4 and 2 (each within the scatter of the next, the first and the last beyond it).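

With 3-methoxyphenyl on this aromatic carbon, this assay gives its first aryl number, and both steps, a 1.9-fold lower number from compound 2 to compound 4 (0.28 log units; within the scatter) and a 1.3-fold higher number from compound 1 to compound 4 (0.12 log units; within the scatter), lie within the scatter. The entering group brings a six-membered aromatic ring and 0 hydrogen-bond donors, so a hydroxyl group on this substituent is not needed for a number in this range. No available measurement explains these steps.

From the compounds shown here alone, whether an amine or a carboxylic acid here would move the number beyond the scatter remains open. So does the contribution of the methoxy group, with an unsubstituted phenyl absent from the compounds shown and compound 3 without a number.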